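The source may hold more compounds than are shown below. What is called first, only, known or untested is meant among the compounds shown, and "the series" means these compounds.

In a functional assay on 1321-N1 cells for agonist activity at P2Y purinoceptor 6 (Homo sapiens), read by scintillation counting and inositol phosphate accumulation (a lower number here means that less compound is needed, a higher number that more compound is needed for the effect), compound 1 `O=c1[nH]/c(=N\OCCCc2ccc(F)cc2)ccn1[C@@H]1O[C@H](COP(=O)(O)OP(=O)(O)OP(=O)(O)O)[C@@H](O)[C@H]1O` gives 1210 nM. Compound 2 `O=c1[nH]/c(=N\OCCCc2ccc(Br)cc2)ccn1[C@@H]1O[C@H](COP(=O)(O)OP(=O)(O)OP(=O)(O)O)[C@@H](O)[C@H]1O` gives 225 nM. Compound 3 `O=c1[nH]/c(=N\OCCCc2ccc(I)cc2)ccn1[C@@H]1O[C@H](COP(=O)(O)OP(=O)(O)OP(=O)(O)O)[C@@H](O)[C@H]1O` gives 90 nM.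

Compound 2 thus stands second among the three numbers: a 5.4-fold lower number from compound 1 to compound 2 (0.73 log units; beyond the scatter), and a 2.5-fold lower number from compound 2 to compound 3 (0.40 log units; beyond the scatter). Compound 4 `O=c1[nH]/c(=N\OCCCc2ccc([N+](=O)[O-])cc2)ccn1[C@@H]1O[C@H](COP(=O)(O)OP(=O)(O)OP(=O)(O)O)[C@@H](O)[C@H]1O` carries the change (nitro in place of bromo on an aromatic carbon). Both measured steps concern halogen exchanges at this position, and none involves a nitro group, so they bear only loosely on the new change. Those halogen steps were modest in size, and the nitro exchange is expected to stay within a comparable span, with a somewhat higher number considered the more likely outcome. Compound 4 is therefore estimated at 400 nM, between 100 nM and 1600 nM, which would correspond to an expected 1.8-fold higher number from compound 2 to compound 4 (0.25 log units; within the scatter).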

Compound 4, half-maximal effective concentration: 1330 nM
The estimate for compound 4 lay 3.3-fold (0.52 log units) below the measured number, within the range that was stated.
By their numbers in this assay, from the lowest: compound 3; then compound 2; then compounds 1 and 4 (each within the scatter of the next).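

In this assay, for the compounds shown here, the first non-halogen group at this position loses the advantage held by the heavier halogens, with a 5.9-fold higher number from compound 2 to compound 4 (0.77 log units; beyond the scatter) and a 15-fold higher number from compound 3 to compound 4 (1.17 log units; beyond the scatter). Its step from the fluoro compound, by contrast, stays within the scatter, with a 1.1-fold higher number from compound 1 to compound 4 (0.04 log units; within the scatter). No measurement at hand accounts for compound 4 falling level with compound 1 rather than with compound 2 or compound 3.

From the compounds shown here alone, whether an amine or a carboxylic acid at this position would match the nitro and fluoro compounds or the bromo and iodo compounds remains open, as does whether a longer chain would preserve these steps.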